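This account rests on a few compounds, and the source may have more. Where it says the series, first, only, none or still open, it means among the compounds named here.

In an ADME assay on HepG2 cells (Homo sapiens) for cytotoxicity, read by luminescence, with a stated time of 72 h (a lower number here means that less compound is needed, a higher number that more compound is needed for the effect), compound 1 (`CCOC(=O)c1c(-c2cccc(-c3ccccc3)c2)[nH]c2cc(Cl)ccc2c1=O`) gives > 21500 nM as a limit only. Compound 2 (`CCOC(=O)c1c(-c2cccc(-c3ccccc3)c2)[nH]c2cc(Cl)c(OC)cc2c1=O`) gives > 21500 nM as a limit too, which leaves it at the limit of > 21500 nM in this assay, at which 2 of the 2 values shown sit, with no exact number. Compound 3 (`CCOC(=O)c1c(-c2cccc(-c3ccccc3)c2)[nH]c2cc(Cl)c(Cl)cc2c1=O`) carries chloro in place of methoxy on an aromatic carbon ortho to a chloro group. Within the data shown here, the only measured step that bears on this, methoxy in place of hydrogen on an aromatic carbon, is a step that the two limits leave unreadable from compound 1 to compound 2 and so offers no size to carry over. No shift beyond the scatter is therefore expected in this assay and another limit is the likeliest report. The expected change is a step that the limit leaves unreadable from compound 2 to compound 3 as an estimate only. For compound 3 the estimated value is 25000 nM with an expected range from 12000 nM to 50000 nM in this read-out.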

Compound 3, half-maximal effective concentration: > 21500 nM
Compound 3: a limit, no number (the forecaster's own chance of this, stated with the estimate: 80%); the middle value does not contradict the limit.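

Compound 3 sits with compound 1 and compound 2 at one limit, so no step among them can be read in this assay: the limit of > 21500 nM in this assay, at which 3 of the 3 values shown sit.

The compounds shown give no exact number, leaving open whether hydrogen, methoxy or chloro at this place changes the concentration needed at all.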